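A few compounds are considered here, and "the series" means these few. Any claim that something is new, unique, unknown or untested is made for them only; others in the source may bear on it.

Of the compounds shown here, two from this study have been tested in a functional assay on MT2 cells (Homo sapiens) for cytotoxicity, read by MTT assay; a higher number here means that more compound is tolerated, a lower number that less compound is tolerated. Compound 1 `Clc1ccc(Nc2nccs2)cc1OCc1cccs1` stands highest of the two numbers, at 38000 nM in this assay. The nearest point is compound 2 `N#Cc1ccc(Nc2nccs2)cc1OCc1cccs1`, which in this assay gives 4100 nM. That step, a 9.3-fold lower number from compound 1 to compound 2 (0.97 log units; beyond the scatter), comes from a cyano in place of chloro on an aromatic carbon, a change on the opposite side of the shared core from the one now at issue.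

Compound 3 `CC1=C(COc2cc(Nc3nccs3)ccc2Cl)CCC1` has not yet been measured in this assay. It differs from compound 1 in one place: 2-methylcyclopent-1-en-1-yl in place of thiophen-2-yl on a saturated chain carbon bound to an oxygen on an aromatic ring. Within the data shown here, no measured step touches this position, so the only step in hand does not bear on it, and the size of the step from compound 1 to compound 3 cannot be read off anything already seen. With no guide either way, the expectation is for a number close to that of compound 1, within a wide band that allows movement in either direction, giving an expected step of a 1.3-fold lower number from compound 1 to compound 3 (0.10 log units; within the scatter). For compound 3 the estimate in this assay is therefore 30000 nM, with a range from 8000 nM to 100000 nM.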

Compound 3, half-maximal cytotoxic concentration: 11000 nM
The estimate for compound 3 lay 2.7-fold (0.44 log units) above the measured number; low and high end bracket the measured number.
By their numbers in this assay, from the lowest: compound 2; then compound 3; then compound 1.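

The group on the saturated chain carbon bound to an oxygen on an aromatic ring is not a silent position in this assay: the swap from thiophen-2-yl to 2-methylcyclopent-1-en-1-yl gives a 3.5-fold lower number from compound 1 to compound 3 (0.54 log units; beyond the scatter) and so moves the number beyond the scatter, something the earlier cyano and chloro pair could not reveal about this end of the molecule. The swap also shows that this place accepts a non-aromatic ring of carbon only, with a double bond outside aromatic rings, in place of an aromatic ring holding sulfur, and the number stays measurable. Nothing at hand explains why this swap moves the number in this direction.

This single swap changes several things at once, namely the sulfur, the aromatic ring and the added methyl, so the compounds shown cannot tell which of these carries the step. A plain phenyl ring, a cyclopentyl ring without the double bond or methyl, a longer carbon chain or an amine at this place would each help to separate those parts.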